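Fluoro for hydrogen on the chloro-bearing ring: cytotoxicity notes

This account rests on a few compounds, and the source may have more. Where it says the series, first, only, none or still open, it means among the compounds named here.

Measured so far in an ADME assay on L6 cells (Rattus norvegicus) for cytotoxicity, read by resazurin assay, with a stated time of 72 h; a lower number here means a stronger inhibitor, a higher number a weaker inhibitor:
compound 1 `OC(c1ccc(Cl)cc1)(c1ccc(C(F)(F)F)cc1)c1cccnc1` gives 56400 nM
compound 2 `OC(c1ccc(Cl)cc1)(c1cccnc1)c1ccc(C(F)(F)F)cc1F` gives 57400 nM
compound 3 `OC(c1ccc(Cl)cc1)(c1cccnc1)c1cccs1` gives 67700 nM

All three values sit close together. The step of a 1.0-fold higher number from compound 1 to compound 2 (0.01 log units; within the scatter) comes from the change fluoro in place of hydrogen on an aromatic carbon and lies within the scatter, so compound 1 and compound 2 are not distinguished in this assay. Compound 3 carries a different core from compound 1; the difference between the two cores is not broken down here. Its value in this assay is within the scatter of both compound 1 and compound 2.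

Compound 4 `OC(c1cccnc1)(c1cccs1)c1ccc(Cl)cc1F` is not yet measured. It arises from compound 3 by fluoro in place of hydrogen on an aromatic carbon. Within the data shown here, this is the same kind of change as the one from compound 1 to compound 2, but not the same: there the fluoro enters meta to a trifluoromethyl group (4 heavy atoms), here it enters meta to a chloro group (1 heavy atom). Among the measured compounds shown here, the only measured precedent, the step of a 1.0-fold higher number from compound 1 to compound 2 (0.01 log units; within the scatter), left the number unchanged within scatter.

For the measured compounds named here, on that basis the step of a 1.0-fold higher number from compound 3 to compound 4 (0.00 log units; within the scatter) is expected to be small, because the only comparable step, a 1.0-fold higher number from compound 1 to compound 2 (0.01 log units; within the scatter), was within the scatter. For compound 4 in this assay the value is estimated at 68000 nM, with a range from 40000 nM to 115000 nM; the estimate rests on compound 3 alone, whose value 67700 nM is the starting point, and on a single precedent.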

Compound 4, half-maximal inhibitory concentration: > 100000 nM
Compound 4 gave a limit, no number; the forecaster's own chance of this, stated with the estimate: 15%; at least 1.4-fold (0.16 log units) between middle value and limit.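

In this assay compound 4 gives > 100000 nM and this is a limit of the assay, not a number. Fluoro in place of hydrogen on an aromatic carbon, here on the ring carrying the chloro group, therefore reads as an at least 1.4-fold higher number from compound 3 to compound 4 (0.16 log units; that floor lies within the scatter) and this gives only a floor for the step, not its size. The result shows neither that the change carries over unchanged from the core of compound 1 to the core of compound 3 nor that it acts differently on the two cores: the same change on two cores in this assay, a 1.0-fold higher number (0.01 log units; within the scatter) from compound 1 to compound 2 and an at least 1.4-fold higher number (0.16 log units; that floor lies within the scatter) from compound 3 to compound 4; the limit leaves it open whether they differ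

Still open, going by these compounds, is how the same change behaves when an amine or a carboxylic acid stands in place of the chloro group on the ring that takes the fluoro. How often the series reaches the limit also remains open, with a single compound there so far: the limit of > 100000 nM in this assay, at which 1 of the 4 values shown sits.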